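The source may hold more compounds than are shown below. What is called first, only, known or untested is meant among the compounds shown, and "the series" means these compounds.

Measured compounds:
compound 1, `Cc1ccc(Sc2cnc(Nc3ccccn3)s2)cc1C(=O)NCC#N`: 44 nM
compound 2, `Cc1ccc(Sc2cnc(Nc3ccccn3)s2)cc1C(=O)NCCO`: 760 nM

Compound 2 holds the highest of the two numbers in an assay on isolated protein for inhibition of high affinity nerve growth factor receptor (Homo sapiens); a lower number here means a stronger inhibitor, a higher number a weaker inhibitor. Going by the values given here, its only neighbour is compound 1, and the one measured step, a 17-fold higher number from compound 1 to compound 2 (1.24 log units; beyond the scatter), separates them. The next compound, compound 3, has the structure `Cc1ccc(Sc2cnc(Nc3ccccn3)s2)cc1NC(=O)CC#N`. Relative to compound 2 the change is ((cyanomethyl)carbonyl)amino in place of (2-hydroxyethyl)carbamoyl on an aromatic carbon. The step from compound 1 to compound 2 bears on this change in part: it swapped a nitrile on the chain for a hydroxymethyl, and compound 3 brings a nitrile back, so that part of the record argues for a markedly lower number than compound 2 gives. Among the compounds with values here, the remaining part of the change, the reversed attachment of the amide to the aromatic carbon, has no measured pair behind it, so the size of its own contribution is unknown. On balance the number for compound 3 is expected to fall between the two measured values, closer to compound 1, with wide bounds, an expected step of a 5.1-fold lower number from compound 2 to compound 3 (0.70 log units; beyond the scatter). The estimate for compound 3 is 150 nM, with a range from 30 nM to 800 nM.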

Compound 3, half-maximal inhibitory concentration: 60 nM
The estimate for compound 3 lay 2.5-fold (0.40 log units) above the measured number, within the range that was stated.
By their numbers in this assay, from the lowest: compounds 1 and 3 (each within the scatter of the next); then compound 2.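

In this assay, turning the amide round on this aromatic carbon, ortho to a methyl group, leaves no difference that can be read: the record gives a 1.4-fold higher number from compound 1 to compound 3 (0.13 log units; within the scatter), so the (cyanomethyl)carbamoyl and ((cyanomethyl)carbonyl)amino groups cannot be told apart here. Against that, the record gives a 13-fold lower number from compound 2 to compound 3 (1.10 log units; beyond the scatter), which sets compound 2, the only one of the three compounds without a nitrile, apart from both of the others, so among these three the number follows the presence of the nitrile and not the direction of the amide. No measurement shown gives a reason for either step, and none accounts for the way the two amide directions match in this assay.

From the compounds shown here alone, the two directions have been compared only with the nitrile in place, so it remains open whether a reversed amide ending in a hydroxyl group would give a number as high as that of compound 2. Going by these compounds, it is also open how a longer chain ending in a nitrile, a chain ending in an amine or one ending in a carboxylic acid would read at this position.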